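This account rests on a few compounds, and the source may have more. Where it says the series, first, only, none or still open, it means among the compounds named here.

Compound 1 `CCN(CC)c1ccc(/C=N/NC(=O)Nc2cc3c(Nc4ccc(F)c(Cl)c4)ncnc3cc2O[C@H]2CCOC2)c(O)c1` gives 15700 nM in a functional assay on A549 cells (Homo sapiens) for cytotoxicity, read by MTT assay, with a stated time of 72 h; a lower number here means a stronger inhibitor, a higher number a weaker inhibitor. Compound 2 `O=C(N/N=C/c1ccc(O)cc1)Nc1cc2c(Nc3ccc(F)c(Cl)c3)ncnc2cc1O[C@H]1CCOC1` differs from it by 4-hydroxyphenyl in place of 4-(diethylamino)-2-hydroxyphenyl on a carbon with a double bond to nitrogen and in this assay compound 2 gives 1320 nM, a step of a 12-fold lower number from compound 1 to compound 2 (1.08 log units; beyond the scatter). Compound 3 `CCN(CC)c1ccc(/C=N/NC(=O)Nc2cc3c(Nc4ccc(F)c(Cl)c4)ncnc3cc2OC)c(O)c1` carries a different core, the difference being (methyl in place of oxolan-3-yl on an oxygen on an aromatic ring); in this assay compound 3 gives 27300 nM, a step of a 1.7-fold higher number from compound 1 to compound 3 (0.24 log units; within the scatter). Compound 4 `COc1cc2ncnc(Nc3ccc(F)c(Cl)c3)c2cc1NC(=O)N/N=C/c1ccc(O)cc1` has not yet been measured. It differs from compound 3 by 4-hydroxyphenyl in place of 4-(diethylamino)-2-hydroxyphenyl on a carbon with a double bond to nitrogen, the same change as that seen between the first two compounds, at the same place. The expectation rests on the earlier step of a 12-fold lower number from compound 1 to compound 2 (1.08 log units; beyond the scatter), and on the core difference having made only a 1.7-fold higher number from compound 1 to compound 3 (0.24 log units; within the scatter). Compound 4 is therefore expected to make a step of a 12-fold lower number from compound 3 to compound 4 (1.07 log units; beyond the scatter). Compound 4 is estimated at 2300 nM, with a range from 900 nM to 6000 nM.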

Compound 4, half-maximal inhibitory concentration: 7610 nM
Beside the measured number, compound 4's estimate is 3.3-fold (0.52 log units) below it; measured number above the stated range.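

In this assay, 4-hydroxyphenyl in place of 4-(diethylamino)-2-hydroxyphenyl again gives a lower number on the core carrying methyl on the oxygen, with a 3.6-fold lower number from compound 3 to compound 4 (0.55 log units; beyond the scatter), but the size of the step does not carry over from the core carrying oxolan-3-yl: the same change on two cores in this assay, a 12-fold lower number (1.08 log units; beyond the scatter) from compound 1 to compound 2 and a 3.6-fold lower number (0.55 log units; beyond the scatter) from compound 3 to compound 4, 3.3-fold (0.52 log units) apart, beyond the scatter of two such steps. Seen from the other place, methyl in place of oxolan-3-yl gives a 5.8-fold higher number from compound 2 to compound 4 (0.76 log units; beyond the scatter), and this step also depends on the partner group: the same change on two cores in this assay, a 1.7-fold higher number (0.24 log units; within the scatter) from compound 1 to compound 3 and a 5.8-fold higher number (0.76 log units; beyond the scatter) from compound 2 to compound 4, 3.3-fold (0.52 log units) apart, beyond the scatter of two such steps. Thus the direction of the change held on these two cores but its size did not, and this single pair shows neither why the steps differ nor how the change would behave on any other core.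

The compounds shown leave open which part of the leaving group matters, since the diethylamino and hydroxyl groups change together. A phenyl ring bearing only a diethylamino group, or an ethyl or cyclopentyl group on the oxygen, could help separate these effects.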